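Fluoro to methyl swap on the fused ring

This account rests on a few compounds, and the source may have more. Where it says the series, first, only, none or still open, it means among the compounds named here.

Compound 1 `Fc1ccc(NC(=S)Nc2nc3ccc(F)cc3s2)cc1` gives 16200 nM in a functional assay on U-937 cells (Homo sapiens) for cytotoxicity, read by MTT assay, with a stated time of 48 h; a lower number here means a stronger inhibitor, a higher number a weaker inhibitor. Compound 2 `Fc1ccc2nc(NC(=S)Nc3ccccc3)sc2c1` reaches only a limit, > 50000 nM, in this assay. For compound 2 the number is thus bounded, not known (the limit of > 50000 nM in this assay, at which 1 of the 2 values shown sits). Among the compounds with values here, the single measured step, an at least 3.0-fold higher number from compound 1 to compound 2 (0.48 log units; beyond the scatter), runs toward weaker inhibition. Compound 3 `Cc1ccc2nc(NC(=S)Nc3ccccc3)sc2c1` is the next member: methyl in place of fluoro on an aromatic carbon. Within the data shown here, no measured step covers methyl entering in place of fluoro, and the change sits on an aromatic carbon of a six-membered aromatic ring of carbon only, part of a fused or bridged system of two rings, a different position from the one changed between compound 1 and compound 2. With compound 2 already at the limit, the step expected in this assay, a step that the limit leaves unreadable from compound 2 to compound 3, is taken as none beyond the scatter. Compound 3 is therefore estimated at 60000 nM, between 20000 nM and 200000 nM, with a limit rather than a number the likelier outcome.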

Compound 3, half-maximal inhibitory concentration: > 50000 nM
Compound 3 ended at the assay's limit; the forecaster's own chance of this, stated with the estimate: 70%; the middle value lies beyond the limit too.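

Compound 2 and compound 3 both sit at a limit in this assay, so no step between them can be read: the limit of > 50000 nM in this assay, at which 2 of the 3 values shown sit.

Still open, from the compounds shown here alone, is whether methyl in place of fluoro changes the number for a compound with a readable value, such as compound 1.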